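Cytotoxicity notes: bicyclic nucleoside sulfonate series, compound 4

The source may hold more compounds than are shown below. What is called first, only, known or untested is meant among the compounds shown, and "the series" means these compounds.

Measured in a functional assay on MT4 cells (Homo sapiens); a higher number here means that more compound is tolerated, a lower number that less compound is tolerated:
compound 1 `Cc1cn([C@@H]2O[C@H](CO[Si](C)(C)C(C)(C)C)[C@@]3(OS(=O)(=O)C=C3NCCC(=O)OCc3ccccc3)[C@H]2O[Si](C)(C)C(C)(C)C)c(=O)n(C)c1=O` gives > 250000 nM
compound 2 `COC(=O)C(=O)CNC1=CS(=O)(=O)O[C@@]12[C@@H](CO[Si](C)(C)C(C)(C)C)O[C@@H](n1cc(C)c(=O)n(C)c1=O)[C@@H]2O[Si](C)(C)C(C)(C)C` gives 10300 nM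
compound 3 `COC(=O)CC(=O)NC1=CS(=O)(=O)O[C@@]12[C@@H](CO[Si](C)(C)C(C)(C)C)O[C@@H](n1cc(C)c(=O)n(C)c1=O)[C@@H]2O[Si](C)(C)C(C)(C)C` gives 11900 nM

The value of compound 1 is a limit of this assay, not a number. Compound 3 stands highest of the two numbers; its nearest neighbour is compound 2, with a 1.2-fold higher number from compound 2 to compound 3 (0.06 log units; within the scatter). Compound 4 `Cc1cn([C@@H]2O[C@H](CO[Si](C)(C)C(C)(C)C)[C@@]3(OS(=O)(=O)C=C3NCC(=O)C(=O)O)[C@H]2O[Si](C)(C)C(C)(C)C)c(=O)n(C)c1=O` differs from compound 3 as follows: (carboxycarbonyl)methyl in place of ((methoxycarbonyl)methyl)carbonyl on an amine nitrogen. For the measured compounds named here, the one measured step on this nitrogen that stays within numbers, a 1.2-fold higher number from compound 2 to compound 3 (0.06 log units; within the scatter), was small; the steps from compound 1, an at least 24-fold lower number from compound 1 to compound 2 (1.38 log units; beyond the scatter) and an at least 21-fold lower number from compound 1 to compound 3 (1.32 log units; beyond the scatter), were large and run against a limit. Going by the values given here, no measured step covers an ester replaced by an acid. For compound 4 a modest rise in this assay is expected, a 3.4-fold higher number from compound 3 to compound 4 (0.53 log units; beyond the scatter), giving an estimate of 40000 nM with a range of 9000 nM to 200000 nM.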

Compound 4, half-maximal cytotoxic concentration: 31100 nM
Estimate against measurement, compound 4: 1.3-fold (0.11 log units) above, within the range that was stated.
By their numbers in this assay, from the lowest: compounds 2 and 3 (each within the scatter of the next); then compound 4. At a limit, above all of these: compound 1.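

Hydrogen in place of methyl on an oxygen next to a carbonyl group is the first change in this assay that replaces an ester with an acid, and it reaches beyond the scatter (a 3.0-fold higher number from compound 2 to compound 4 (0.48 log units; beyond the scatter)). The change on the amine nitrogen, with (carboxycarbonyl)methyl in place of ((methoxycarbonyl)methyl)carbonyl, is also modest (a 2.6-fold higher number from compound 3 to compound 4 (0.42 log units; beyond the scatter)). Compound 1 stands at a limit, not a number, so its step can be read only as a bound (an at least 8.0-fold lower number from compound 1 to compound 4 (0.90 log units; beyond the scatter)): the limit of > 250000 nM in this assay, at which 1 of the 4 values shown sits.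

As far as these compounds go, how a primary amine, or a longer chain ending in the carboxylic acid, would read on this nitrogen remains open.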